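Swapping the aryl amide: methoxy out, chlorine in

This account rests on a few compounds, and the source may have more. Where it says the series, first, only, none or still open, it means among the compounds named here.

Of the compounds shown here, two have been tested in a functional assay on GLC82 cells (Homo sapiens) for cytotoxicity, read by MTT assay, with a stated time of 72 h; on this read-out higher numbers stand for weaker inhibition and lower numbers for stronger inhibition. Compound 1 `COc1cc2ncnc(NNC(=S)NC(=O)c3ccc(Cl)cc3)c2cc1OC` carries a chlorine on its aryl amide and two methoxy groups on its shared core; in this assay compound 1 gives 9620 nM. Compound 2 `COc1ccccc1C(=O)NC(=S)NNc1ncnc2ccccc12` has a plain core and a methoxy-bearing aryl amide; in this assay compound 2 gives 9500 nM. These two numbers sit essentially on top of each other, within the usual scatter, so neither compound can be called stronger than the other; both act only at high concentration.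

Compound 3 `O=C(NC(=S)NNc1ncnc2ccccc12)c1cccc(Cl)c1` is the next step, taken from compound 2 by a single change: 3-chlorophenyl in place of 2-methoxyphenyl on a carbonyl carbon. Because compound 1, which also carries a chlorophenyl amide, gives 9620 nM, a chlorine on this ring is not expected to move the read-out far from where the methoxy analogue stands. The step from compound 2 to compound 3 is expected to be small, in no fixed direction, and to stay within the scatter, at about a 1.1-fold lower number from compound 2 to compound 3 (0.02 log units; within the scatter). Compound 3 is therefore estimated at 9000 nM, with a plausible range from 4000 nM to 20000 nM.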

Compound 3, half-maximal inhibitory concentration: 3240 nM
Beside the measured number, compound 3's estimate is 2.8-fold (0.44 log units) above it, and the stated range ends above it.
By their numbers in this assay, from the lowest: compound 3; then compounds 2 and 1 (each within the scatter of the next).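

In this assay, changing the aryl group on a carbonyl carbon gives a 2.9-fold lower number from compound 2 to compound 3 (0.47 log units; beyond the scatter) and shows that the read-out does respond to the aryl group at this place. Compounds 1 and 2 could not show this: they differ in more than one place, so their closeness said nothing about the aryl group alone. The change also has two parts, since a methoxy group leaves, a chlorine enters and the substituent's ring position differs, and no measurement here explains the shift or assigns it to either part.

The compounds shown leave open how much of the step belongs to the chlorine and how much to where it sits on the ring, and whether any substituent is needed at all, a question that a plain phenyl group would address. They also leave open how this place tolerates quite different groups, such as a phenyl ring carrying an amine or a carboxylic acid, and whether the 3-chlorophenyl group would give a similar step on the core of compound 1.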